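Notes on compound 3 against the two measured analogues

This account rests on a few compounds, and the source may have more. Where it says the series, first, only, none or still open, it means among the compounds named here.

Two compounds carry numbers in an assay on cells for agonist activity at ecdysone receptor (Bombyx mori), read by a luciferase reporter, with a stated time of 24 h; a higher number here means that more compound is needed for the effect, a lower number that less compound is needed. Compound 1 `CC(C)(C)N(NC(=O)c1ccccc1Br)C(=O)c1ccccc1Cl` gives 316 nM. Compound 2 `CC(C)(C)N(NC(=O)c1ccc(C#N)cc1)C(=O)c1ccccc1Cl` gives 603 nM, the highest of the two numbers, with compound 1 as its nearest neighbour; the step of a 1.9-fold higher number from compound 1 to compound 2 (0.28 log units; within the scatter) stays within the scatter, so no order between the two can be read. Compound 3 `CC(C)(C)N(NC(=O)c1cccc(Cl)c1Cl)C(=O)c1ccccc1Cl` is not yet measured. It differs from compound 2 by 2,3-dichlorophenyl in place of 4-cyanophenyl on a carbonyl carbon. For the measured compounds named here, only one measured step bears on this change, a 1.9-fold higher number from compound 1 to compound 2 (0.28 log units; within the scatter), which exchanged one substituted phenyl for another on the same carbonyl carbon and stayed within the scatter. The return to a halogen-bearing phenyl in compound 3 is therefore expected to move the number at most modestly, if anything downward toward compound 1, whose value 316 nM is the closest guide. For compound 3 the estimate is 280 nM, with a range from 90 nM to 900 nM. The expected step is a 2.2-fold lower number from compound 2 to compound 3 (0.33 log units; beyond the scatter).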

Compound 3, half-maximal effective concentration: 9.33 nM
Compound 3: middle estimate off by 30-fold (1.48 log units), on the high side; measured number below the stated range.
By their numbers in this assay, from the lowest: compound 3; then compounds 1 and 2 (each within the scatter of the next).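

The aryl group on this carbonyl carbon can shift the number strongly: in this assay the change to 2,3-dichlorophenyl gives a 65-fold lower number from compound 2 to compound 3 (1.81 log units; beyond the scatter) and also a 34-fold lower number from compound 1 to compound 3 (1.53 log units; beyond the scatter) even though the earlier exchange of aryl groups stayed within the scatter. A halogen on the phenyl ring is not enough to explain the drop, since compound 1 also carries one, as 2-bromophenyl, and remains within the scatter of compound 2, which has none. Nothing available here gives a measured reason for the large step.

The three compounds cannot show whether both chlorines are needed or whether one would give most of the drop. Also open, as far as these compounds go, is how a 2,3-dimethylphenyl or 2,3-dimethoxyphenyl group would compare on the same carbonyl carbon.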